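Aryl variation on the ring amine in a flat series

A few compounds are considered here, and "the series" means these few. Any claim that something is new, unique, unknown or untested is made for them only; others in the source may bear on it.

Compound 1 `Nc1scc(CN2CCN(c3ccc(Cl)cc3Cl)CC2)c1C(=O)c1ccc(Cl)cc1` gives 0% in an assay on CHO cells for displacement of a labelled ligand from adenosine receptor A3 (Homo sapiens), read by scintillation counting, with a stated time of 120 min, tested at 10 uM; a lower number here means less inhibition, a higher number more inhibition at the concentration tested (going by the name of the read-out).
Compound 2 `Nc1scc(CN2CCN(c3ccc(Cl)c(C(F)(F)F)c3)CC2)c1C(=O)c1ccc(Cl)cc1` gives 3% in this assay.

For the measured compounds named here, compound 2 stands highest of the two numbers measured so far, but its nearest neighbour is compound 1, and the only measured step, a number 3 percentage points higher from compound 1 to compound 2 (within the scatter), lies within the scatter: replacing the 2,4-dichlorophenyl on the amine nitrogen in the ring with 4-chloro-3-(trifluoromethyl)phenyl left the read-out essentially unchanged at a level close to zero.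

Compound 3 `Nc1scc(CN2CCN(c3c(Cl)cccc3Cl)CC2)c1C(=O)c1ccc(Cl)cc1` is not yet measured. It differs from compound 2 in one place: 2,6-dichlorophenyl in place of 4-chloro-3-(trifluoromethyl)phenyl on an amine nitrogen in a ring. Going by the values given here, the one step that bears on this change, from compound 1 to compound 2, swapped one substituted phenyl on the same ring nitrogen for another without moving the number beyond the scatter, and both measured values sit near the floor of the read-out. No step beyond the scatter is therefore expected for compound 3, with an estimated step of a number 1 percentage points lower from compound 2 to compound 3 (within the scatter). Compound 3 is expected to give 2% in this assay, within a range of 0% to 12%.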

Compound 3, a percentage reported as inhibition, at one concentration (the size of the read-out at that concentration, not a potency): 1%
Estimate against measurement, compound 3: 1 percentage points above; the range from low to high includes it.
By their numbers in this assay, from the lowest: compounds 1, 3 and 2 (each within the scatter of the next).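

In this assay, a number 2 percentage points lower from compound 2 to compound 3 (within the scatter) and a number 1 percentage points higher from compound 1 to compound 3 (within the scatter), so both steps lie within the scatter and a third chlorinated or trifluoromethyl-bearing phenyl pattern on the amine nitrogen in a ring leaves the series flat. The change from 4-chloro-3-(trifluoromethyl)phenyl, with 11 heavy atoms, to 2,6-dichlorophenyl, with 8, separates nothing, and neither does moving the chlorines within the dichlorophenyl pair, compound 1 and compound 3. Nothing available accounts for this flatness.

Open, from the compounds shown here alone, is whether a group of another kind on this nitrogen, such as a phenyl bearing a carboxylic acid or an amine, or a pyridine ring in place of the phenyl, would lift the number. Also open, going by these compounds, is whether a change elsewhere on the shared core would make this position respond at all.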